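Methoxy in place of hydroxymethyl: three measured, one expected

The source may hold more compounds than are shown below. What is called first, only, known or untested is meant among the compounds shown, and "the series" means these compounds.

Measured so far in a functional assay on Caco-2 cells (Homo sapiens) for activation, read by fluorescence, tested at 1 uM; on this read-out lower numbers stand for a stronger effect and higher numbers for a weaker effect at the one concentration tested:
Compound 1, `O=C(/C=C(/C=C/c1ccc(O)cc1)NCCCO)/C=C/c1ccc(O)cc1`, gives 94.1%.
Compound 2, `COc1cc(/C=C/C(=O)/C=C(/C=C/c2ccc(O)c(OC)c2)NCCCO)ccc1O`, gives 93.4%.
Compound 3, `COCCNC(=C\C(=O)/C=C/c1ccc(O)cc1)/C=C/c1ccc(O)cc1`, gives 94.9%.

All three numbers lie close together, and none of the gaps between them reaches beyond the usual scatter of this assay, so no ordering among compounds 1, 2 and 3 can be read from them. Compound 3 is compound 1 with one change, (methoxy in place of hydroxymethyl on a saturated chain carbon, two bonds along the chain from an amine nitrogen), and that change made a step of a number 0.8 percentage points higher from compound 1 to compound 3 (within the scatter). Compound 2 shares a chain with compound 1 but differs on the rings; how the two cores differ is not broken down here.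

Compound 4, `COCCNC(=C\C(=O)/C=C/c1ccc(O)c(OC)c1)/C=C/c1ccc(O)c(OC)c1`, is not yet measured. It stands to compound 2 as compound 3 stands to compound 1: the change is methoxy in place of hydroxymethyl on a saturated chain carbon, two bonds along the chain from an amine nitrogen, the same change at the same place. Among the compounds with values here, for this assay the only evidence about that change is the pair compound 1 to compound 3, whose step stayed within the scatter. On that basis the expected step from compound 2 to compound 4 is a number 0.8 percentage points higher from compound 2 to compound 4 (within the scatter), resting on the measured step of a number 0.8 percentage points higher from compound 1 to compound 3 (within the scatter) and on the value of compound 2, 93.4%. Compound 4 is therefore estimated at 94.2%, with a range expected from 88% to 100%.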

Compound 4, a percentage reported as activity, at one concentration (the size of the read-out at that concentration, not a potency): 105%
For compound 4 the middle estimate is 10.8 percentage points below the measured one; measured number outside the range, above it.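

On the core of compound 2, putting methoxy in place of hydroxymethyl gives in this assay a clear result: a number 11.6 percentage points higher from compound 2 to compound 4 (beyond the scatter) is a step large enough to read, and since a higher number stands for a weaker effect here, compound 4 does less than compound 2 at the one concentration tested. Within the data shown here, this does not show that the change acts differently on the two cores, even though only one of its two steps stands out from the scatter, and it offers no reason for the larger step. A single step can stand out while the comparison of two steps does not, as each step carries the scatter of both its compounds, and so the gap between the steps must be larger before it means anything, which it does not reach here: the same change on two cores in this assay, a number 0.8 percentage points higher (within the scatter) from compound 1 to compound 3 and a number 11.6 percentage points higher (beyond the scatter) from compound 2 to compound 4, 10.8 percentage points apart, within the scatter of two such steps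

With only one pair on each core, the compounds shown leave open whether the larger step or the smaller one is the better guide to what this change does on a further core. They also leave open what a longer chain, an amine or a carboxylic acid would do in place of the methoxy on either core.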